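Methyl Ester in Place of Ethyl Ester on a Shared Core

The compounds below may be only part of what the source reports. "The series", "measured", "known", "first", "only" and "open" are said of these compounds alone.

Of the compounds shown here, three on one shared core have been measured in a functional assay on MCF7 cells (Homo sapiens) for antiproliferative activity, read by MTT assay, with a stated time of 48 h; a higher number here means a weaker inhibitor, a lower number a stronger inhibitor. Compound 2 `CCOC(=O)/C(=C/c1ccccc1)CN1C(=O)[C@@H](OC)[C@H]1c1ccc(F)cc1` gives 18800 nM. Compound 3 `CCOC(=O)/C(=C/c1ccccc1)CN1C(=O)[C@@H](OC)[C@H]1c1cccc([N+](=O)[O-])c1` gives 19900 nM, and the step of a 1.1-fold higher number from compound 2 to compound 3 (0.02 log units; within the scatter) changes the aryl group on a saturated ring carbon. Compound 1 `COC(=O)/C(=C/c1ccccc1)CN1C(=O)[C@@H](OC)[C@H]1c1ccc(Cl)cc1`, a methyl ester with a chlorophenyl group, gives 15300 nM. All three numbers lie within the scatter of one another, so compound 2 stands in a flat group. Compound 4 `COC(=O)/C(=C/c1ccccc1)CN1C(=O)[C@@H](OC)[C@H]1c1ccc(F)cc1` differs from compound 2 only by hydrogen in place of methyl on a saturated chain carbon bound to an oxygen next to a carbonyl group. Going by the values given here, no measured step isolates this change. The estimate therefore assumes no step beyond the scatter: compound 4 is expected at 17000 nM, between 8000 nM and 36000 nM, a step of a 1.1-fold lower number from compound 2 to compound 4 (0.04 log units; within the scatter).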

Compound 4, half-maximal inhibitory concentration: 15600 nM
Compound 4: the middle estimate sits 1.1-fold (0.04 log units) above what was measured, and the stated range covers the measured number.
By their numbers in this assay, from the lowest: compounds 1, 4, 2 and 3 (each within the scatter of the next).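

Going from ethoxycarbonyl to methoxycarbonyl now has a step of its own in this assay (a 1.2-fold lower number from compound 2 to compound 4 (0.08 log units; within the scatter)), so on this core, with the 4-fluorophenyl group kept, the shorter ester leaves the number unchanged within the scatter. The new compound also gives a halogen comparison with the ester held as methyl: fluoro in place of chloro on an aromatic carbon gives a 1.0-fold higher number from compound 1 to compound 4 (0.01 log units; within the scatter) and again stays within the scatter. No evidence is at hand that bears on either step. Going by these compounds, whether a longer chain such as butyl, or a free carboxylic acid in place of the ester, would shift the number stays open.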